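Acyl variation on the shared core: outlook for compound 3

The source may report more compounds than this note shows. Statements on the series, on what has been measured and on what is new or still open speak of the compounds shown alone.

Measured in an assay on cells (Epithelial cell) with Cystic fibrosis transmembrane conductance regulator variant F508del (Homo sapiens) as the target, read by fluorescence, with a stated time of 20 h (on this read-out lower numbers stand for stronger inhibition and higher numbers for weaker inhibition), so far:
- compound 1 `COc1ccc(Cl)cc1Nc1nc2c(s1)CCCCc1nc(NC(=O)C3CC3)sc1-2` gives 4500 nM
- compound 2 `COc1ccc(Cl)cc1Nc1nc2c(s1)CCCCc1nc(NC(=O)C(C)C)sc1-2` gives 8700 nM

Among the compounds with values here, compound 2 has the highest of the two numbers, with compound 1 as its only neighbour; the step of a 1.9-fold higher number from compound 1 to compound 2 (0.29 log units; within the scatter) is within the scatter, so the two acyl groups on the carbonyl carbon cannot be told apart on these data.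

The next compound, compound 3 `COC(=O)CCC(=O)Nc1nc2c(s1)-c1nc(Nc3cc(Cl)ccc3OC)sc1CCCC2`, differs from compound 2 in one place: 2-(methoxycarbonyl)ethyl in place of isopropyl on a carbonyl carbon. Within the data shown here, the only measured step that touches the same position is the one from compound 1 to compound 2, an exchange of one small acyl group for another, and it stayed within the scatter. Among the measured compounds shown here, the change to compound 3 is of a different kind, bringing in the 2-(methoxycarbonyl)ethyl chain and its two hydrogen-bond acceptors, for which no precedent exists. Expected, then, is a step of about a 1.1-fold higher number from compound 2 to compound 3 (0.06 log units; within the scatter) in this assay, with no confident direction beyond the scatter and a wide range. For compound 3 the estimate in this assay is 10000 nM, between 4000 nM and 25000 nM.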

Compound 3, half-maximal inhibitory concentration: 8300 nM
Compound 3: the middle estimate sits 1.2-fold (0.08 log units) above what was measured; the measured number falls inside the stated range.
By their numbers in this assay, from the lowest: compounds 1, 3 and 2 (each within the scatter of the next).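

In this assay the steps of a 1.0-fold lower number from compound 2 to compound 3 (0.02 log units; within the scatter) and a 1.8-fold higher number from compound 1 to compound 3 (0.27 log units; within the scatter) both lie within the scatter, so 2-(methoxycarbonyl)ethyl cannot be told apart from either isopropyl or cyclopropyl at this position. Within the data shown here, the earlier pair compared only two small groups; this change goes from 3 heavy atoms and 0 hydrogen-bond acceptors in isopropyl to 6 heavy atoms and 2 hydrogen-bond acceptors in the entering chain, still without a step beyond the scatter. On a carbonyl carbon whose other neighbour is an amide-type nitrogen, these three compounds therefore show no trend with the size of the group or its count of hydrogen-bond acceptors.

Going by these compounds, whether a carboxylic acid in place of the methoxycarbonyl end, an amine on the chain or a longer chain would produce a step beyond the scatter remains open. On these data alone, all three compounds also share the rest of the core, so how changes elsewhere on it would affect this read-out remains open too.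

No other evidence bears on this result.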